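Acetyl in place of the alkynyl carbinol on the shared core

This account rests on a few compounds, and the source may have more. Where it says the series, first, only, none or still open, it means among the compounds named here.

Measured so far:
compound 1, `CC#CCC(O)(c1ccc(N2CCN(S(=O)(=O)c3ccc(N)nc3)C[C@@H]2C#CC)cc1)C(F)(F)F`, 115 mL.min-1.g-1
compound 2, `CC#C[C@H]1CN(S(=O)(=O)c2ccc(N)nc2)CCN1c1ccc(S(=O)(=O)NCC2CC2)cc1`, 213 mL.min-1.g-1
compound 3, `C#CCC(O)(c1ccc(N2CCN(S(=O)(=O)c3ccc(N)nc3)C[C@@H]2C#CC)cc1)C(F)(F)F`, 59 mL.min-1.g-1

Within the data shown here, in an ADME assay (liver) for metabolic stability, with Liver microsome (Rattus norvegicus) as the target, using microsomes and NADPH, with a stated time of 30 min (a higher number here means faster removal of the compound, a lower number slower removal), compound 3 gives the lowest of the three numbers, though its step to compound 1 is within the scatter and only the step to compound 2 lies beyond it. Compound 4, `CC#C[C@H]1CN(S(=O)(=O)c2ccc(N)nc2)CCN1c1ccc(C(C)=O)cc1`, differs from compound 3 by a group of 3 heavy atoms (2 carbon, 1 oxygen; no ring) in place of a group of 9 heavy atoms (5 carbon, 1 oxygen, 3 fluorine; no ring), on an aromatic carbon. Among the measured compounds shown here, the steps that bear on this are the two other replacements at the same aromatic carbon, a 1.9-fold higher number from compound 1 to compound 2 (0.27 log units; within the scatter) and a 3.6-fold lower number from compound 2 to compound 3 (0.56 log units; beyond the scatter), both modest or within the scatter. A comparable change is therefore expected, direction uncertain, as a 1.4-fold higher number from compound 3 to compound 4 (0.13 log units; within the scatter). Compound 4 is estimated at 80 mL.min-1.g-1, with a range from 30 mL.min-1.g-1 to 220 mL.min-1.g-1.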

Compound 4, intrinsic clearance in microsomes: 249 mL.min-1.g-1
Beside the measured number, compound 4's estimate is 3.1-fold (0.49 log units) below it; the measured number lies above the stated range.
By their numbers in this assay, from the lowest: compounds 3, 1, 2 and 4 (each within the scatter of the next, the first and the last beyond it).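

In this assay, acetyl at this aromatic carbon gives a 4.2-fold higher number from compound 3 to compound 4 (0.63 log units; beyond the scatter) and a 2.2-fold higher number from compound 1 to compound 4 (0.34 log units; beyond the scatter), so it separates from both alkynyl carbinols. Against (cyclopropylmethyl)sulfamoyl, the change gives a 1.2-fold higher number from compound 2 to compound 4 (0.07 log units; within the scatter), so these two groups cannot be told apart here despite their different sizes. Of the groups shown at this position, only the alkynyl carbinols therefore stand apart from acetyl, and only compound 3 is separated from both other groups. From the compounds shown here alone, whether an amine or a carboxylic acid here would read like acetyl or like the carbinols remains open. Nothing given here explains the separation.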